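Pyridin-2-yl in place of 2-cyanoethyl on a carbonyl carbon

A few compounds are considered here, and "the series" means these few. Any claim that something is new, unique, unknown or untested is made for them only; others in the source may bear on it.

In a physicochemical assay for solubility, measured as kinetic solubility, with a stated time of 1 h, at pH 7.4 (on this read-out lower numbers stand for lower solubility and higher numbers for higher solubility), compound 1 `CC(=O)NC1=NN(c2ccc(Cl)c(Cl)c2)CC1` gives 31000 nM and compound 2 `N#CCCC(=O)NC1=NN(c2ccc(Cl)c(Cl)c2)CC1` gives 39000 nM which places compound 2 within the usual scatter of compound 1. Among the compounds with values here, the only measured step, cyanomethyl in place of hydrogen on a saturated chain carbon bound to a carbonyl carbon, is a 1.3-fold higher number from compound 1 to compound 2 (0.10 log units; within the scatter) and so shows no change beyond that scatter.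

Compound 3 `O=C(NC1=NN(c2ccc(Cl)c(Cl)c2)CC1)c1ccccn1` carries pyridin-2-yl in place of 2-cyanoethyl on a carbonyl carbon, a change counted as pyridin-2-yl in place of 2-cyanoethyl on a carbonyl carbon and one that brings in a six-membered aromatic ring. Within the data shown here, the measured step bears on this only loosely: it altered a chain, and no measured compound carries a ring on this carbonyl carbon. This swap is still a larger structural change than the one behind a 1.3-fold higher number from compound 1 to compound 2 (0.10 log units; within the scatter) and a modest move to a lower number is expected in this assay this time. The estimated size is a 2.4-fold lower number from compound 2 to compound 3 (0.39 log units; beyond the scatter) and it remains uncertain. For compound 3 the estimate is 16000 nM with 6000 nM and 40000 nM as the expected lower and upper ends.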

Compound 3, solubility: 11000 nM
Estimate against measurement, compound 3: 1.5-fold (0.16 log units) above; the range from low to high includes it.
By their numbers in this assay, from the lowest: compound 3; then compounds 1 and 2 (each within the scatter of the next).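

In this assay, within the data shown here, pyridin-2-yl in place of 2-cyanoethyl on the carbonyl carbon gives a 3.5-fold lower number from compound 2 to compound 3 (0.55 log units; beyond the scatter) and is the first step in this small set to lie beyond the scatter, which the earlier change within the chain did not do. The same ring in place of methyl on that carbonyl carbon points the same way and gives a 2.8-fold lower number from compound 1 to compound 3 (0.45 log units; beyond the scatter) so the lower number appears against both ring-free groups shown here, and neither compound goes against this pattern among these three compounds. No supporting measurement is available to say what lies behind this lower number.

The three compounds leave open whether the lower number goes with the aromatic ring as such or with the nitrogen inside it, a question that a plain phenyl ring on the same carbonyl carbon could help to settle. Also open, going by these compounds, is whether a saturated ring such as piperidine or morpholine, or a longer chain ending in an amine or a carboxylic acid, would sit with pyridin-2-yl or with the two ring-free groups.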